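Swapping fluoro for methoxy: how long will compound 4 last?

The source may report more compounds than this note shows. Statements on the series, on what has been measured and on what is new or still open speak of the compounds shown alone.

Measured in an ADME assay on cells (Hepatocyte, Mus musculus) for metabolic stability; a lower number here means that the compound disappears faster, a higher number that the compound lasts longer:
- compound 1 `CS(=O)(=O)NC1CCC(CN2CCN(c3cc(=O)c4cc(C(F)(F)F)cc([N+](=O)[O-])c4s3)CC2)CC1`: > 1.55 h (a limit of the assay, not a number)
- compound 2 `O=C(OC1CCC(CN2CCN(c3cc(=O)c4cc(C(F)(F)F)cc([N+](=O)[O-])c4s3)CC2)CC1)c1ccc(C(F)(F)F)cc1`: 0.278 h
- compound 3 `O=C(OC1CCC(CN2CCN(c3cc(=O)c4cc(C(F)(F)F)cc([N+](=O)[O-])c4s3)CC2)CC1)c1ccc(F)cc1`: 0.0817 h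

Among the compounds with values here, only two of these values are actual numbers. Compound 3 stands lowest of them at 0.0817 h, and compound 2 gives 0.278 h. Compound 1 has only a limit, > 1.55 h.

The next structure, compound 4 `COc1ccc(C(=O)OC2CCC(CN3CCN(c4cc(=O)c5cc(C(F)(F)F)cc([N+](=O)[O-])c5s4)CC3)CC2)cc1`, differs from compound 3 in one group: methoxy in place of fluoro on an aromatic carbon. In words, methoxy sits in place of fluoro on an aromatic carbon, para to a large group.

Within the data shown here, two measured steps bear on this. The closer one is a 3.4-fold lower number from compound 2 to compound 3 (0.53 log units; beyond the scatter), with fluoro in place of trifluoromethyl on an aromatic carbon. It is modest, though beyond the scatter. The other, an at least 18-fold lower number from compound 1 to compound 3 (1.27 log units; beyond the scatter), is large, but it exchanges a different group on a saturated ring carbon, so it offers little guidance here.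

Among the measured compounds shown here, with only one modest swap of this kind as a guide, no step beyond the scatter is expected in this assay, with a slight rise the likelier direction. The expected change is a 1.3-fold higher number from compound 3 to compound 4 (0.13 log units; within the scatter). Compound 4 is estimated at 0.11 h, with an expected range from 0.05 h to 0.25 h.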

Compound 4, half-life: 0.295 h
For compound 4 the middle estimate is 2.7-fold (0.43 log units) below the measured one, outside the stated range (above it).
By their numbers in this assay, from the lowest: compound 3; then compounds 2 and 4 (each within the scatter of the next). At a limit, above all of these: compound 1.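

In this assay, fluoro on this aromatic carbon, para to a large group, no longer stands against trifluoromethyl alone: replacing it with methoxy gives a 3.6-fold higher number from compound 3 to compound 4 (0.56 log units; beyond the scatter), a step beyond the scatter and of modest size. Methoxy and trifluoromethyl at this place cannot be told apart, with a 1.1-fold higher number from compound 2 to compound 4 (0.03 log units; within the scatter), which lies within the scatter, so among these three groups it is fluoro alone that goes with the lowest number. Changing this one group does not close the gap left by the larger exchange on the saturated ring carbon, where the methanesulfonamido group gives way to ((4-methoxyphenyl)carbonyl)oxy: an at least 5.2-fold lower number from compound 1 to compound 4 (0.72 log units; beyond the scatter).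

On these data alone, how far that gap reaches stays unknown, since compound 1 has a limit and not a number: the limit of > 1.55 h in this assay, at which 1 of the 4 values shown sits. With only three groups shown at this aromatic carbon, it remains open whether an amine, a carboxylic acid or a longer chain such as ethoxy would fall with fluoro or with methoxy and trifluoromethyl.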